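Acetamido in Place of Chloro: What Compound 4 May Give

The source may report more compounds than this note shows. Statements on the series, on what has been measured and on what is new or still open speak of the compounds shown alone.

Compound 1 `CN(CCCN1CCN(c2ccccc2)CC1)c1cccc(Cl)c1` was tested in an assay on HEK293 cells for displacement of a labelled ligand from 5-hydroxytryptamine receptor 7 (Homo sapiens), read by scintillation counting, with a stated time of 30 min (a lower number here means a stronger inhibitor, a higher number a weaker inhibitor), and gives 179 nM. Among the three measured compounds it holds the second highest number: compound 2 `CN(CCCN1CCN(c2cccc3ccccc23)CC1)c1cccc(O)c1` gives 2.9 nM and compound 3 `CN(CCCN1CCN(c2ccc3ccccc3c2)CC1)c1cccc(O)c1` gives 434 nM, so compound 1 sits below compound 3 and far above compound 2. Compound 4 `CC(=O)Nc1cccc(N(C)CCCN2CCN(c3ccccc3)CC2)c1` has not yet been measured. It differs from compound 1 in one place: acetamido in place of chloro on an aromatic carbon. Among the measured compounds shown here, no measured pair shows this change, and compounds 2 and 3 differ from compound 1 in more than one place, so they offer no direct guide. The step of a 1.4-fold higher number from compound 1 to compound 4 (0.15 log units; within the scatter) is expected to be modest, toward a weaker inhibitor or none beyond the scatter. Compound 4 is therefore expected to give about 250 nM, within 50 nM to 1200 nM.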

Compound 4, inhibition constant: 161 nM
Compound 4: the middle estimate sits 1.6-fold (0.19 log units) above what was measured; the range from low to high includes it.
By their numbers in this assay, from the lowest: compound 2; then compounds 4 and 1 (each within the scatter of the next); then compound 3.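

In this assay, acetamido in place of chloro gives a 1.1-fold lower number from compound 1 to compound 4 (0.05 log units; within the scatter). This position on the aromatic ring therefore accepts a larger group, one that brings a hydrogen-bond donor and a hydrogen-bond acceptor, with no change beyond the scatter. Nothing available explains why the two groups read alike.

As far as these compounds go, whether an amine, a carboxylic acid or a longer acyl chain on the nitrogen would read the same at this position remains open. So does whether acetamido would behave this way on the core of compound 2.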